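Swapping the methylsulfonylphenyl arm for a pyridine ring

The source may hold more compounds than are shown below. What is called first, only, known or untested is meant among the compounds shown, and "the series" means these compounds.

Measured compounds:
compound 1, `CS(=O)(=O)c1ccc(-c2cnc3[nH]cc(-c4nnc(-c5ccc(F)cc5)o4)c(=O)c3c2)cc1`: 39.5%
compound 2, `CS(=O)(=O)c1ccc(-c2cnc3[nH]cc(-c4nnc(-c5ccccc5)o4)c(=O)c3c2)cc1`: 27.2%

In a functional assay on HCT-116 cells (Homo sapiens) for positive allosteric modulation, read by MTT assay, with stated times of 24 h and 48 h, tested at 2.5 uM (on this read-out lower numbers stand for less inhibition of growth and higher numbers for more inhibition of growth at the one concentration tested), compound 1 gives 39.5% and stands highest of the two numbers measured. Its nearest neighbour is compound 2, which in this assay gives 27.2%; the step of a number 12.3 percentage points lower from compound 1 to compound 2 (beyond the scatter) is the only measured one, and it concerns the fluoro on the outer phenyl ring.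

Compound 3, `O=c1c(-c2nnc(-c3ccc(F)cc3)o2)c[nH]c2ncc(-c3ccncc3)cc12`, has not yet been measured. It differs from compound 1 at another place: pyridin-4-yl in place of 4-(methylsulfonyl)phenyl on an aromatic carbon. The shared core and the fluorophenyl-bearing ring stay as they are in compound 1.

For the measured compounds named here, no measured step touches this position, so the single step from compound 1 to compound 2 does not bear on the change, and there is nothing to say whether replacing the methylsulfonylphenyl group will raise or lower the number. The expectation rests on compound 1 alone, with a wide range around it. Compound 3 is therefore estimated at 32%, within 12% to 52%, which would mean an expected step of a number 7.5 percentage points lower from compound 1 to compound 3 (within the scatter) that may well stay within the scatter.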

Compound 3, percent growth inhibition at one concentration: 19.6%
Estimate against measurement, compound 3: 12.4 percentage points above; low and high end bracket the measured number.
By their numbers in this assay, from the lowest: compounds 3 and 2 (each within the scatter of the next); then compound 1.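

In this assay, for the compounds shown here, putting pyridin-4-yl in place of 4-(methylsulfonyl)phenyl gives a number 19.9 percentage points lower from compound 1 to compound 3 (beyond the scatter), the first reading at this position on the shared core. It shows that the group on this aromatic carbon, para to a fused ring, does affect the number: with the fluorophenyl-bearing side left as it is, the 4-(methylsulfonyl)phenyl arm goes with more growth inhibition at the one concentration tested, and compound 1 remains the highest of the three compounds. No measurement shown here explains why the number falls with this change.

The change replaces the benzene ring with a pyridine ring and also removes the methylsulfonyl group, so the compounds shown cannot say which of these two differences accounts for the step. Going by these compounds, an unsubstituted phenyl ring or a phenyl ring carrying a carboxylic acid at this position would help to separate them, and it also remains open whether removing the fluoro from the outer ring would change the number in the same way when pyridin-4-yl is present.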